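Replacing a Cyclopropyl Group with a Double Bond

The source may report more compounds than this note shows. Statements on the series, on what has been measured and on what is new or still open speak of the compounds shown alone.

Three related compounds have numbers in a functional assay on A549 cells (Homo sapiens) for cytotoxicity, read by MTT assay; a lower number here means a stronger inhibitor, a higher number a weaker inhibitor. Compound 1 `CCCCCCCCC1CC1CCCCCCCC(=O)OC[C@H](CO[C@@H]1O[C@H](CO)[C@@H](O)[C@H](O)[C@H]1O)OC(=O)CCCCCCCC1CC1CCCCCCCC` gives 124000 nM, the highest of the three numbers. Compound 2 `C=CCCCCCCCCC(=O)OC[C@H](CO[C@@H]1O[C@H](CO)[C@@H](O)[C@H](O)[C@H]1O)OC(=O)CCCCCCCCC=C` gives 106000 nM, and the usual scatter of repeated measurements does not separate it from compound 1. Compound 3 `CCCCCCCCCCCC(=O)OC[C@H](CO[C@@H]1O[C@H](CO)[C@@H](O)[C@H](O)[C@H]1O)OC(=O)CCCCCCCCCCC` gives 35600 nM, a number lower than that of compound 1 by more than the scatter.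

Compound 4 `CCCCCCCC/C=C\CCCCCCCC(=O)O[C@H](COC(=O)CCCCCCCC1CC1CCCCCCCC)CO[C@@H]1O[C@H](CO)[C@@H](O)[C@H](O)[C@H]1O` has no number yet. It differs from compound 1 as follows: dec-1-en-1-yl in place of 2-octylcyclopropyl on a saturated chain carbon, seven bonds along the chain from a carbonyl carbon. In words, dec-1-en-1-yl stands in place of 2-octylcyclopropyl on a saturated chain carbon, seven bonds along the chain from a carbonyl carbon.

Within the data shown here, no measured pair isolates this change, so any forecast is loose. The chains can matter, as compound 3 at 35600 nM shows, yet compound 2 at 106000 nM stays level with compound 1. The expected result is therefore no change beyond the scatter, with a slight lean towards a lower number. The estimated step is a 1.2-fold lower number from compound 1 to compound 4 (0.09 log units; within the scatter). Compound 4 is estimated at 100000 nM, within an expected range of 45000 nM to 200000 nM.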

Compound 4, half-maximal inhibitory concentration: 41600 nM
The estimate for compound 4 lay 2.4-fold (0.38 log units) above the measured number; the whole stated range lies above it.
By their numbers in this assay, from the lowest: compounds 3 and 4 (each within the scatter of the next); then compounds 2 and 1 (each within the scatter of the next).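

In this assay, this place on the chain does respond to the change. Among these compounds, with dec-1-en-1-yl in place of 2-octylcyclopropyl on a single chain, the step is a 3.0-fold lower number from compound 1 to compound 4 (0.47 log units; beyond the scatter), the only comparison here that isolates one change, and it shows that altering one chain while the other keeps its 2-octylcyclopropyl is enough to move the number beyond the scatter. Nothing measured here explains why the ring and the double bond give different numbers.

Still open, from the compounds shown here alone, is whether making the same replacement on the second chain would lower the number further. It is also unknown whether a trans double bond or a fully saturated chain of the same length at this place would behave like dec-1-en-1-yl.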